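Swapping an iodo for a furan-2-yl on a nucleoside core

A few compounds are considered here, and "the series" means these few. Any claim that something is new, unique, unknown or untested is made for them only; others in the source may bear on it.

Compound 1 `COc1ncnc2c1c(I)cn2[C@@H]1O[C@H](CO)[C@@H](O)[C@H]1O` is a sugar-bearing nucleoside whose core carries an iodo group. For the measured compounds named here, in a functional assay on HeLa S3 cells (Homo sapiens) for antiproliferative activity, read by XTT assay, with a stated time of 72 h (on this read-out higher numbers stand for weaker inhibition and lower numbers for stronger inhibition), compound 1 gives 14300 nM, which is the only numerical value in this small set. Compound 2 `CNc1ncnc2c1c(-c1ccccc1)cn2[C@@H]1O[C@H](CO)[C@@H](O)[C@H]1O` reaches only > 20000 nM in this assay, and this is a limit of the assay rather than a number. Compound 3 `O=c1[nH]cnc2c1c(-c1cc3ccccc3o1)cn2[C@@H]1O[C@H](CO)[C@@H](O)[C@H]1O` likewise stands at > 20000 nM in this assay, again a limit of the assay. Going by the values given here, compound 1 therefore stands alone as the one compound with a measured value, while the other two sit at the limit of > 20000 nM in this assay, at which 2 of the 3 values shown sit.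

Compound 4 `COc1ncnc2c1c(-c1ccco1)cn2[C@@H]1O[C@H](CO)[C@@H](O)[C@H]1O` has not yet been tested. Compared with compound 1 it shows the change (furan-2-yl in place of iodo on an aromatic carbon). Among the compounds with values here, no step between measured compounds is available to guide the size of this move, so the expectation rests on a guess: the step of a 36-fold lower number from compound 1 to compound 4 (1.55 log units; beyond the scatter) is expected to be a gain in potency beyond the usual scatter. Compound 4 is accordingly estimated at 400 nM, within a range from 30 nM to 6000 nM.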

Compound 4, half-maximal inhibitory concentration: 1020 nM
Compound 4: the middle estimate sits 2.6-fold (0.41 log units) below what was measured, and the stated range covers the measured number.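

At this aromatic carbon of the shared core, a five-membered aromatic ring can take the place of a single iodine atom with a large gain: in this assay the swap to furan-2-yl gives a 14-fold lower number from compound 1 to compound 4 (1.15 log units; beyond the scatter). For the compounds shown here, this is the first step in the set that can be read, and it shows that this position responds strongly to the group it carries. Compound 2 and compound 3 also bear aromatic rings at this carbon but differ elsewhere on the core as well, and each stands at a limit of the assay, not a number: the limit of > 20000 nM in this assay, at which 2 of the 4 values shown sit.

On these data alone, it remains open whether a thiophene ring, with sulfur in place of the furan oxygen, or a simple amine at this carbon would give a similar result. Also open, as far as these compounds go, is whether furan-2-yl would bring the same gain on the cores of compound 2 or compound 3.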